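The source may hold more compounds than are shown below. What is called first, only, known or untested is meant among the compounds shown, and "the series" means these compounds.

Measured in a physicochemical assay for lipophilicity, read by HPLC, at pH 7.5; on this read-out lower numbers stand for lower lipophilicity and higher numbers for higher lipophilicity:
- compound 1 `CC[C@@H](Nc1c(C#N)c(-c2ccc(-c3ncccc3C)cc2)nc2cnccc12)C(N)=O`: 2
- compound 2 `CCOc1ccccc1-c1ccc(-c2nc3cnccc3c(N[C@H](CC)C(N)=O)c2C#N)cc1`: 3

Compound 2, at 3, holds the higher of the two numbers. Compound 3 `CC[C@@H](Nc1c(C#N)c(-c2ccc(-c3ccccc3Cl)cc2)nc2cnccc12)C(N)=O` carries chloro in place of ethoxy on an aromatic carbon, chloro in place of ethoxy on an aromatic carbon, ortho to a large group. Among the compounds with values here, one measured step bears on this only indirectly: a number 1.00 log units higher from compound 1 to compound 2 (beyond the scatter), a modest step that exchanges 3-methylpyridin-2-yl for 2-ethoxyphenyl, not one group for another on the same ring. The estimated step is a number 0.10 log units lower from compound 2 to compound 3 (within the scatter), so none beyond the scatter is expected in this assay. For compound 3 the expected value is 2.9, with an estimated range of 2.4 to 3.4.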

Compound 3, distribution coefficient: 2.9
Compound 3: the middle estimate sits on the measured number at the digits printed, and the stated range covers the measured number.
By their numbers in this assay, from the lowest: compound 1; then compounds 3 and 2 (each within the scatter of the next).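

In this assay, chloro in place of ethoxy on this aromatic carbon, ortho to a large group, gives a number 0.10 log units lower from compound 2 to compound 3 (within the scatter), so at this place the two groups are not told apart. 2-chlorophenyl in place of 3-methylpyridin-2-yl gives a number 0.90 log units higher from compound 1 to compound 3 (beyond the scatter), which shows that a second 2-substituted phenyl, not only 2-ethoxyphenyl, stands beyond the scatter from compound 1. No evidence in hand accounts for either step.

On these data alone, whether an amine or a carboxylic acid at this place would also stay within the scatter of compound 2 remains open. So does the effect of a longer alkoxy chain.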